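The source may hold more compounds than are shown below. What is called first, only, known or untested is meant among the compounds shown, and "the series" means these compounds.

Compound 1 `CNC(=O)CCCCCCCn1nc(-c2cnc3[nH]ccc3c2)c2c(N)ncnc21`: 29100 nM
Compound 2 `Nc1ncnc2c1c(-c1cnc3[nH]ccc3c1)nn2CC(=O)NO`: "not determined" (no result reported)

In a functional assay on HeLa cells (Homo sapiens) for inhibition, read by MTT assay, with a stated time of 72 h (on this read-out lower numbers stand for stronger inhibition and higher numbers for weaker inhibition), compound 1 gives 29100 nM. Within the data shown here, this is the only number available, since compound 2 has no reported result, so compound 1 cannot yet be ranked against anything. What can be said is that its value leaves plenty of room for a stronger result.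

Compound 3 `Nc1ncnc2c1c(-c1cnc3[nH]ccc3c1)nn2CCCCCCCCC(=O)NO` keeps the shared core and changes the far end of the chain: (hydroxycarbamoyl)methyl in place of methylcarbamoyl on a saturated chain carbon, seven bonds along the chain from an aromatic nitrogen. Put simply, (hydroxycarbamoyl)methyl stands in place of methylcarbamoyl on a saturated chain carbon, seven bonds along the chain from an aromatic nitrogen.

Among the measured compounds shown here, no measured pair shows what this exchange does, and compound 2, which also carries a hydroxycarbamoyl end, offers no number to help. The expectation is therefore a judgement and is loosely held: a clear gain in inhibition, well beyond the usual scatter, rather than no change. The expected change is a 29-fold lower number from compound 1 to compound 3 (1.46 log units; beyond the scatter). Compound 3 is estimated at 1000 nM, with an expected range of 150 nM to 8000 nM.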

Compound 3, half-maximal inhibitory concentration: 7470 nM
Estimate against measurement, compound 3: 7.5-fold (0.87 log units) below; measured number inside the range.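

The far end of this chain clearly counts for something: in this assay, putting (hydroxycarbamoyl)methyl in place of methylcarbamoyl on a saturated chain carbon, seven bonds along the chain from an aromatic nitrogen, gives a 3.9-fold lower number from compound 1 to compound 3 (0.59 log units; beyond the scatter) as a modest gain that lies beyond the usual scatter. The exchange changes two things at once, since the end group differs and 3-(methylcarbamoyl)propyl becoming 4-(hydroxycarbamoyl)butyl also makes the chain longer, so this single step cannot assign the gain to either one. No measurement shown here accounts for the step.

Still open, on these data alone, is whether the hydroxycarbamoyl end or the extra chain length matters more, a question that a methylcarbamoyl end on the longer chain or a carboxylic acid at the same end could help to settle. Among these compounds, compound 2 has no reported result, so no step involving it can be read, and the effect of chain length with a hydroxycarbamoyl end remains unknown.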